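Swapping a methoxy for a cyclopropylcarbonylamino group

The source may hold more compounds than are shown below. What is called first, only, known or untested is meant among the compounds shown, and "the series" means these compounds.

Measured so far:
- compound 1 `COc1cccc(-c2csc(NC(=O)c3ccc([N+](=O)[O-])o3)n2)c1`: 58700 nM
- compound 2 `O=C(Nc1nc(-c2cccc(F)c2)cs1)c1ccc([N+](=O)[O-])o1`: 51600 nM
- compound 3 `O=C(Nc1nc(-c2c(F)cc(F)cc2F)cs1)c1ccc([N+](=O)[O-])o1`: 19900 nM

In an ADME assay on Vero cells (Chlorocebus sabaeus) for cytotoxicity, read by MTT assay, with a stated time of 72 h (a higher number here means a weaker inhibitor, a lower number a stronger inhibitor), compound 1 gives the highest number of the three, with compound 2 nearest and compound 3 furthest away. The unmeasured compound 4 `O=C(Nc1nc(-c2cccc(NC(=O)C3CC3)c2)cs1)c1ccc([N+](=O)[O-])o1` differs from compound 1 in one place: (cyclopropylcarbonyl)amino in place of methoxy on an aromatic carbon. Among the measured compounds shown here, the one measured step at the same place is the swap of fluoro for methoxy, a 1.1-fold lower number from compound 1 to compound 2 (0.06 log units; within the scatter), which stayed within the scatter. For the measured compounds named here, the new group is larger than either fluoro or methoxy, and no measured step covers a group of that kind, so a step of the size seen from compound 1 to compound 2 in this assay is expected, or none beyond the scatter. For compound 4 the expected step is a 1.3-fold lower number from compound 1 to compound 4 (0.12 log units; within the scatter). The estimate for compound 4 is 45000 nM, between 20000 nM and 100000 nM.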

Compound 4, half-maximal inhibitory concentration: 35700 nM
Beside the measured number, compound 4's estimate is 1.3-fold (0.10 log units) above it, within the range that was stated.
By their numbers in this assay, from the lowest: compounds 3, 4, 2 and 1 (each within the scatter of the next, the first and the last beyond it).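

In this assay this aromatic carbon now carries a much larger group, (cyclopropylcarbonyl)amino, with its own three-membered ring, and both new steps stay within the scatter (a 1.6-fold lower number from compound 1 to compound 4 (0.22 log units; within the scatter); a 1.4-fold lower number from compound 2 to compound 4 (0.16 log units; within the scatter)). Methoxy, fluoro and this amide group thus give numbers that cannot be told apart at this place, even though the new group differs far more in size. Nothing measured here explains why the numbers stay so close. The compounds shown leave open whether an amine or a carboxylic acid at this place would move the number beyond the scatter.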